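Methoxy-to-chloro swap on the benzyl group of compound 3

The source may report more compounds than this note shows. Statements on the series, on what has been measured and on what is new or still open speak of the compounds shown alone.

Compound 3 `COc1ccc(CC(C)C(=O)N2CCN(c3ccc(C(F)(F)F)cc3[C@@H](N)CC(C)C)CC2)cc1` stands highest of the three numbers in an assay on HEK293 cells for displacement of a labelled ligand from Melanocortin receptor 4 (Homo sapiens) (on this read-out lower numbers stand for stronger inhibition and higher numbers for weaker inhibition), at 120 nM; nearest to it is compound 2 `Cc1ccc(N2CCN(C(=O)[C@H](C)Cc3ccc(Cl)cc3F)CC2)c([C@@H](N)CC(C)C)c1` with 20 nM, and furthest is compound 1 `COc1cc(Cl)ccc1C[C@@H](C)C(=O)N1CCN(c2ccc(C)cc2[C@@H](N)CC(C)C)CC1` with 8.1 nM. Compound 4 `CC(C)C[C@H](N)c1cc(C(F)(F)F)ccc1N1CCN(C(=O)[C@H](C)Cc2ccc(Cl)cc2)CC1` differs from compound 3 by 1-(4-chlorobenzyl)ethyl in place of 1-(4-methoxybenzyl)ethyl on a carbonyl carbon.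

Going by the values given here, the only measured step touching a substituent on that aromatic ring is a 2.5-fold higher number from compound 1 to compound 2 (0.39 log units; beyond the scatter), a modest loss on exchanging one small group for another. That step does not match the present change in group or in position, so it gives direction only loosely. More telling is that both compound 1 and compound 2 carry the 1-(4-chlorobenzyl)ethyl group and sit well below compound 3, though they also differ from compound 3 elsewhere, so a pattern cannot be claimed from them alone.

The expectation for compound 4 is therefore a lower number than compound 3, a step of about a 3.0-fold lower number from compound 3 to compound 4 (0.48 log units; beyond the scatter), with wide uncertainty. Compound 4 is estimated at 40 nM, within a range of 12 nM to 130 nM.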

Compound 4, inhibition constant: 31 nM
Beside the measured number, compound 4's estimate is 1.3-fold (0.11 log units) above it, within the range that was stated.
By their numbers in this assay, from the lowest: compound 1; then compounds 2 and 4 (each within the scatter of the next); then compound 3.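

In this assay, going by these compounds alone, the change gives a 3.9-fold lower number from compound 3 to compound 4 (0.59 log units; beyond the scatter), the first reading at this position with the rest of the molecule held constant: on a carbonyl carbon, 1-(4-chlorobenzyl)ethyl is favoured over 1-(4-methoxybenzyl)ethyl in the trifluoromethyl compounds. The entering group also has one defined stereocentre and the leaving group has none, so this step combines the exchange of chloro for methoxy with that difference in definition. Nothing at hand accounts for the size or direction of the step.

On these data alone, it remains open whether the same exchange gives a similar step when methyl replaces trifluoromethyl on the shared core, and how a bromo or nitrile group would read in place of the chloro. The two configurations at the stereocentre of the entering group also remain to be separated.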